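The source may report more compounds than this note shows. Statements on the series, on what has been measured and on what is new or still open speak of the compounds shown alone.

Measured so far:
compound 1 `C/C=C/C#Cc1ccc(CCC(=O)O)c(F)c1` with 209 nM
compound 2 `C/C(C#Cc1ccc(CCC(=O)O)c(F)c1)=C/CO` with 427 nM

Within the data shown here, in a functional assay on 1321-N1 cells for agonist activity at Free fatty acid receptor 1 (Homo sapiens), read by calcium flux, with a stated time of 0.4 s (a lower number here means that less compound is needed, a higher number that more compound is needed for the effect), compound 2 gives 427 nM, the higher of the two numbers; its only neighbour is compound 1, which gives 209 nM, the gap being a 2.0-fold higher number from compound 1 to compound 2 (0.31 log units; beyond the scatter). Compound 3 `C=C(C)C#Cc1ccc(CCC(=O)O)c(F)c1` differs from compound 2 by 1-methylethenyl in place of 3-hydroxy-1-methylprop-1-en-1-yl on a triple-bonded carbon, so the triple bond again carries a small alkenyl group, much as in compound 1. Only a 2.0-fold higher number from compound 1 to compound 2 (0.31 log units; beyond the scatter) bears on this change, and it ran the other way, so a step back toward compound 1 is expected. Compound 3 is therefore estimated at 250 nM, likely between 100 nM and 600 nM, which means an expected 1.7-fold lower number from compound 2 to compound 3 (0.23 log units; within the scatter).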

Compound 3, half-maximal effective concentration: 81.3 nM
Estimate against measurement, compound 3: 3.1-fold (0.49 log units) above, and the stated range ends above it.
By their numbers in this assay, from the lowest: compound 3; then compound 1; then compound 2.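

In this assay, 1-methylethenyl in place of 3-hydroxy-1-methylprop-1-en-1-yl on a triple-bonded carbon gives a 5.3-fold lower number from compound 2 to compound 3 (0.72 log units; beyond the scatter) and so reverses more than the earlier loss. The same group in place of prop-1-en-1-yl gives a 2.6-fold lower number from compound 1 to compound 3 (0.41 log units; beyond the scatter) and shows that this position distinguishes even two closely related alkenyl groups. Nothing available explains these differences.

Still open, on these data alone, is how an amine or a longer carbon chain on the triple-bonded carbon would compare. These three compounds also cannot separate the hydroxy group's contribution from that of the rest of the chain in compound 2.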